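The source may hold more compounds than are shown below. What is called first, only, known or untested is meant among the compounds shown, and "the series" means these compounds.

Measured so far in an assay on isolated protein for binding affinity to corticotropin-releasing factor receptor 1 (Homo sapiens); a higher number here means a weaker inhibitor, a lower number a stronger inhibitor: compound 1 `CCCN(CCC)c1cc(C)nc2c(-c3ncc(I)cc3C)c(C)nn12` gives 6.6 nM; compound 2 `CCCN(CCC)c1cc(C)nc2c(-c3ncc(C)cc3OC)c(C)nn12` gives 25 nM.

Within the data shown here, compound 2 holds the higher of the two numbers; its only neighbour is compound 1, with a 3.8-fold higher number from compound 1 to compound 2 (0.58 log units; beyond the scatter). Compound 3 `CCCN(CCC)c1cc(C)nc2c(-c3ncc(C)cc3O)c(C)nn12` differs from compound 2 in one place: hydrogen in place of methyl on an oxygen on an aromatic ring. Among the measured compounds shown here, the single measured step swaps the entire substituent on that aromatic carbon rather than the methoxy alone, so no measured step bears directly on this change. A step of modest size is expected, more likely toward a higher number in this assay, a 2.4-fold higher number from compound 2 to compound 3 (0.38 log units; beyond the scatter). For compound 3 the estimate is 60 nM, within a range of 15 nM to 250 nM.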

Compound 3, inhibition constant: > 10000 nM
Compound 3: only a limit was reported; the forecaster's own chance of this, stated with the estimate: 5%; middle value at least 160-fold (2.22 log units) from the limit.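

In this assay the result for compound 3 is a limit, not a number: the limit of > 10000 nM in this assay, at which 1 of the 3 values shown sits. Methoxy to hydroxy, a change of one methyl to hydrogen on the oxygen, gives an at least 400-fold higher number from compound 2 to compound 3 (2.60 log units; beyond the scatter), a far larger step than the earlier 3.8-fold higher number from compound 1 to compound 2 (0.58 log units; beyond the scatter). Against the iodo compound, the replacement of the whole substituent on the aromatic carbon reads an at least 1500-fold higher number from compound 1 to compound 3 (3.18 log units; beyond the scatter), so this position accepts the methoxy but not the hydroxy within the measured range.

The compounds shown leave open how an ethoxy, an amino group or a fluorine at this place would read.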